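Methyl in Place of Fluoro on the Amine-Bound Ring

This account rests on a few compounds, and the source may have more. Where it says the series, first, only, none or still open, it means among the compounds named here.

Measured compounds:
compound 1 `COc1ccc(NCn2nc(-c3ccc4c(c3)OCCO4)oc2=S)cc1` gives 5830 nM
compound 2 `Fc1ccccc1NCn1nc(-c2ccc3c(c2)OCCO3)oc1=S` gives 6390 nM
compound 3 `S=c1oc(-c2ccc3c(c2)OCCO3)nn1CNc1ccc(Br)cc1Br` gives 6410 nM

All three share one core and differ only in the aryl group attached to the amine nitrogen. In a functional assay, with a stated time of 6 min (a lower number here means a stronger inhibitor, a higher number a weaker inhibitor), compound 2 has the second highest of the three numbers. Its nearest neighbour is compound 3, with a 1.0-fold higher number from compound 2 to compound 3 (0.00 log units; within the scatter), and the furthest is compound 1, with a 1.1-fold higher number from compound 1 to compound 2 (0.04 log units; within the scatter). Both steps are within the scatter, so the three values cannot be told apart.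

Compound 4 `Cc1ccccc1NCn1nc(-c2ccc3c(c2)OCCO3)oc1=S` is the next member of the series. It differs from compound 2 as follows: methyl in place of fluoro on an aromatic carbon.

Every measured step bears on this change, since each one also swaps the aryl group on the amine nitrogen: a 1.1-fold higher number from compound 1 to compound 2 (0.04 log units; within the scatter), a 1.1-fold higher number from compound 1 to compound 3 (0.04 log units; within the scatter) and a 1.0-fold higher number from compound 2 to compound 3 (0.00 log units; within the scatter). None of them moved the number beyond the scatter, whether the group carried a methoxy, a fluoro or two bromo substituents. The swap of a fluoro for a methyl is a smaller change than any of those, so no step beyond the scatter is expected in this assay either.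

Compound 4 is therefore expected to give about 6400 nM, with a range from 3200 nM to 12800 nM. The expected step from compound 2 is a 1.0-fold higher number from compound 2 to compound 4 (0.00 log units; within the scatter).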

Compound 4, half-maximal inhibitory concentration: 3450 nM
For compound 4 the middle estimate is 1.9-fold (0.27 log units) above the measured one; measured number inside the range.
By their numbers in this assay, from the lowest: compounds 4, 1, 2 and 3 (each within the scatter of the next).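

In this assay, methyl in place of fluoro on the aromatic carbon ortho to a large group gives a small step (a 1.9-fold lower number from compound 2 to compound 4 (0.27 log units; within the scatter)), so this position accepts a carbon group as well as a halogen without a step beyond the scatter. Swapping the whole aryl group on the amine nitrogen reads the same way (a 1.9-fold lower number from compound 3 to compound 4 (0.27 log units; within the scatter)) and again (a 1.7-fold lower number from compound 1 to compound 4 (0.23 log units; within the scatter)), which places 2-methylphenyl in one band with the 4-methoxyphenyl, 2-fluorophenyl and 2,4-dibromophenyl groups, and the four numbers cannot be told apart. The series therefore now spans a methyl, a methoxy and two kinds of halogen on this ring with no clear separation in the read-out, and no measurement at hand explains this flat picture.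

The compounds shown leave open whether any group at this position can move the number beyond the scatter, in either direction. An amine, a carboxylic acid or a longer chain such as propyl on the same aromatic carbon would test this, as would a plain phenyl ring with no substituent at all.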